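This account rests on a few compounds, and the source may have more. Where it says the series, first, only, none or still open, it means among the compounds named here.

Compound 1 `O=C(/C=C/C=C/c1ccc(Cl)cc1)N1CCCCC1` was tested in an assay for inhibition of Polyunsaturated fatty acid 5-lipoxygenase (Homo sapiens), read by spectrophotometry, tested at 20 uM (a lower number here means less inhibition, a higher number more inhibition at the concentration tested (going by the name of the read-out)), where compound 1 gives 14.5%. Among the compounds with values here, of the two numbers measured so far, compound 1 stands at the low end, though it is not separated from compound 2 `CC(=O)Oc1ccc(/C=C/C=C/C(=O)N2CCCCC2)cc1` beyond the scatter: in this assay compound 2 gives 18.3%, and the step of a number 3.8 percentage points higher from compound 1 to compound 2 (within the scatter) lies within the scatter. Compound 3 `COc1ccc(/C=C/C=C/C(=O)N2CCCCC2)cc1` has not yet been measured. It differs from compound 1 in one place: methoxy in place of chloro on an aromatic carbon. Within the data shown here, the only measured step that bears on this change, the replacement of chloro on an aromatic carbon by another group, is a number 3.8 percentage points higher from compound 1 to compound 2 (within the scatter), which stayed within the scatter. The expected step in this assay is therefore a number 1.5 percentage points higher from compound 1 to compound 3 (within the scatter), small and in no clear direction. Compound 3 is estimated to give about 16% in this assay, with a range from 5% to 30%.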

Compound 3, a percentage reported as inhibition, at one concentration (the size of the read-out at that concentration, not a potency): 42.6%
Compound 3: middle estimate off by 26.6 percentage points, on the low side; measured number outside the range, above it.
By their numbers in this assay, from the lowest: compounds 1 and 2 (each within the scatter of the next); then compound 3.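

In this assay, this position, para to a large group, now shows a step beyond the scatter: a number 28.1 percentage points higher from compound 1 to compound 3 (beyond the scatter), with methoxy in place of chloro. An oxygen on the aromatic carbon does not by itself account for this, as compound 2 also carries one there yet stays within the scatter of compound 1, while replacing its acetyl with methyl gives a number 24.3 percentage points higher from compound 2 to compound 3 (beyond the scatter). Nothing available here explains why methoxy stands apart from chloro and acetoxy.

The compounds shown leave open whether this step is particular to methoxy or would also appear with a longer ether such as ethoxy, a free hydroxyl or an amine at the same place. They also leave open whether methoxy would give a similar step elsewhere on the ring.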